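A hydroxymethyl on the saturated ring of compound 2

This account rests on a few compounds, and the source may have more. Where it says the series, first, only, none or still open, it means among the compounds named here.

Compound 1 `Cc1c(C)n(C(=O)N2CCCCC2)oc1=O`: 13 nM
Compound 2 `Cc1c(C(C)C)c(=O)on1C(=O)N1CCCCC1`: 2 nM
Compound 3 `Cc1c(C(C)C)c(=O)on1C(=O)N(C)CC(N)=O`: only a limit, > 1000 nM

In an assay (strain Wistar) for inhibition of Hormone-sensitive lipase (Rattus norvegicus), read by spectrophotometry (a higher number here means a weaker inhibitor, a lower number a stronger inhibitor), compound 2 holds the lowest of the two numbers; the step of a 6.5-fold lower number from compound 1 to compound 2 (0.81 log units; beyond the scatter) separates it from compound 1. Compound 4 `Cc1c(C(C)C)c(=O)on1C(=O)N1CCCC(CO)C1` differs from compound 2 by hydroxymethyl in place of hydrogen on a saturated ring carbon. Within the data shown here, one measured step touches the same carbonyl substituent: an at least 500-fold higher number from compound 2 to compound 3 (2.69 log units; beyond the scatter), where the ring itself is lost. Compound 3 reaches (the limit of > 1000 nM in this assay, at which 1 of the 3 values shown sits). Compound 4 keeps the ring and only adds a hydroxymethyl on it, so a far smaller change is expected; the step of a 4.0-fold higher number from compound 2 to compound 4 (0.60 log units; beyond the scatter) is expected to be a small rise, near the edge of the scatter. Compound 4 is therefore estimated at 8 nM, with a range from 2 nM to 40 nM.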

Compound 4, half-maximal inhibitory concentration: 180 nM
Compound 4: the middle estimate sits 23-fold (1.35 log units) below what was measured; measured number outside the range, above it.
By their numbers in this assay, from the lowest: compound 2; then compound 1; then compound 4. At a limit, above all of these: compound 3.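

In this assay, the ring can stay intact and a single added hydroxymethyl on a saturated ring carbon still gives a 90-fold higher number from compound 2 to compound 4 (1.95 log units; beyond the scatter). Among the earlier compounds, a loss on this side appeared only with the ring gone, in compound 3, whose value is a limit and not a number: the limit of > 1000 nM in this assay, at which 1 of the 4 values shown sits. This ring carbon, two ring bonds from the ring nitrogen, therefore does not accept substitution freely.

The compounds shown leave open whether a methyl, a methoxymethyl or an aminomethyl on the same carbon would behave like hydroxymethyl. They also leave open whether hydroxymethyl on another ring carbon would cost as much.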